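Aryl sulfonyl series: methoxy in place of naphthalen-2-yl

This account rests on a few compounds, and the source may have more. Where it says the series, first, only, none or still open, it means among the compounds named here.

compound 1 `CC1CCN(C2CCN(S(=O)(=O)c3cccnc3Cl)CC2)CC1`: > 10000 nM
compound 2 `Cc1cccc(S(=O)(=O)N2CCC(N3CCC(C)CC3)CC2)c1`: > 5000 nM
compound 3 `CC1CCN(C2CCN(S(=O)(=O)c3cccc(-c4ccc5ccccc5c4)c3)CC2)CC1`: > 5000 nM

In an ADME assay on HCT-116 cells (Homo sapiens) for cytotoxicity, read by CellTiter-Glo, with a stated time of 72 h (on this read-out lower numbers stand for stronger inhibition and higher numbers for weaker inhibition), compound 3 gives > 5000 nM as a limit, not a number. Compound 1 gives > 10000 nM as a limit too. Compound 2 gives > 5000 nM as a limit as well, with methyl on the aromatic carbon that changes next.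

Compound 4 `COc1cccc(S(=O)(=O)N2CCC(N3CCC(C)CC3)CC2)c1` follows from compound 3 by methoxy in place of naphthalen-2-yl on an aromatic carbon on an aromatic carbon of the ring. Among the compounds with values here, two measured steps bear on this change: a step that the two limits leave unreadable from compound 1 to compound 2 and a step that the two limits leave unreadable from compound 2 to compound 3. Neither gives a size, so no series trend can be read from them. With both methyl in compound 2 and naphthalen-2-yl in compound 3 ending in limits in this assay, no measurable cytotoxicity is expected from methoxy either.

The expected change is a step that the limit leaves unreadable from compound 3 to compound 4 and it remains an estimate with no supported direction. The estimated value for compound 4 is 8000 nM with a range from 3000 nM to 20000 nM and a report as a limit is the likeliest outcome.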

Compound 4, half-maximal inhibitory concentration: > 5000 nM
Compound 4: a limit, no number; the forecaster's own chance of this, stated with the estimate: 85%; the middle value is on the limit's open side.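

In this assay compound 4 gives > 5000 nM, a limit and not a number. No new step can be read between compound 4 and compound 1, compound 2 or compound 3. The compounds shown leave open whether any group on the aryl sulfonyl series gives a measurable value in this assay.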